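A few compounds are considered here, and "the series" means these few. Any claim that something is new, unique, unknown or untested is made for them only; others in the source may bear on it.

Three compounds share one core and differ only in the group on an amide-type nitrogen. Compound 1 `CC(C)c1ccc(NC(=O)[C@H]2CN(C)C[C@@H]2c2ccc(/C=C/C(=O)Nc3ccccc3N)cc2)cc1` gives 54 mL/min/kg in an in vitro ADME assay on microsomes from liver (Mus musculus) for pharmacokinetics, read by LC-MS, with a stated time of 10 min, tested at 1 uM; a higher number here means faster removal of the compound, a lower number slower removal. Compound 2 `CN1C[C@H](C(=O)Nc2cccc(Cl)c2)[C@@H](c2ccc(/C=C/C(=O)Nc3ccccc3N)cc2)C1` gives 58 mL/min/kg in this assay, and compound 3 `CN1C[C@H](C(=O)Nc2ccc(F)c(F)c2)[C@@H](c2ccc(/C=C/C(=O)Nc3ccccc3N)cc2)C1` gives 46 mL/min/kg in this assay. Compound 3 has the lowest of the three numbers, yet its gap to compound 1, the nearest, and to compound 2, the furthest, both lie within the scatter.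

Compound 4 `CC(C)NC(=O)[C@H]1CN(C)C[C@@H]1c1ccc(/C=C/C(=O)Nc2ccccc2N)cc1` has not yet been measured. It differs from compound 3 in one place: isopropyl in place of 3,4-difluorophenyl on an amide-type nitrogen. The measured steps touch the same nitrogen, but each of them trades one six-membered aromatic ring of carbon only for another; none trades such a ring for a group with no ring, so they bear on the new step only loosely. Those steps were a 1.1-fold higher number from compound 1 to compound 2 (0.03 log units; within the scatter), a 1.2-fold lower number from compound 1 to compound 3 (0.07 log units; within the scatter) and a 1.3-fold lower number from compound 2 to compound 3 (0.10 log units; within the scatter), all within the scatter, and on that record the author expects no step beyond the scatter from compound 3 to compound 4, namely a 1.0-fold lower number from compound 3 to compound 4 (0.01 log units; within the scatter). Compound 4 is therefore estimated to give 45 mL/min/kg in this assay, with a range from 25 mL/min/kg to 80 mL/min/kg.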

Compound 4, clearance: 12 mL/min/kg
The estimate for compound 4 lay 3.8-fold (0.57 log units) above the measured number; the measured number lies below the stated range.
By their numbers in this assay, from the lowest: compound 4; then compounds 3, 1 and 2 (each within the scatter of the next).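

Going by these compounds alone, the position is not as indifferent as the earlier compounds suggested: their three aromatic groups on this amide-type nitrogen stayed within the scatter of one another in this assay, whereas replacing any of them with isopropyl gives a step beyond the scatter. The change gives a 3.8-fold lower number from compound 3 to compound 4 (0.58 log units; beyond the scatter) and a 4.8-fold lower number from compound 2 to compound 4 (0.68 log units; beyond the scatter) and also a 4.5-fold lower number from compound 1 to compound 4 (0.65 log units; beyond the scatter), so the drop in the number appears from all three starting points, whichever substituents the aromatic ring carries, and no listed compound goes against it. Nothing shown explains why the number falls at this position.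

In this single change the six-membered aromatic ring disappears and the group on the nitrogen becomes smaller, so the compounds shown cannot say whether the absence of a ring, the smaller group or something else accounts for the step. Going by these compounds, a cyclohexyl group would keep a ring without the aromatic one, while a longer chain such as n-butyl would have no ring but more carbon, and how either would stand in this assay remains open, as does the effect of an amine or a carboxylic acid at the end of such a chain.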